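A few compounds are considered here, and "the series" means these few. Any claim that something is new, unique, unknown or untested is made for them only; others in the source may bear on it.

Compound 1 `CN(C)C(=S)NN=Cc1nccc2ccccc12`: 73.7 nM
Compound 2 `CN(C)C(=S)NN=Cc1nccc2cc(F)ccc12`: 21.6 nM
Compound 3 `CNC(=S)N/N=C/c1nccc2ccccc12`: 331 nM

In a functional assay on MIA PaCa-2 cells (Homo sapiens) for cytotoxicity, read by luminescence, with a stated time of 72 h, in the presence of a further agent that is not named here (a lower number here means a stronger inhibitor, a higher number a weaker inhibitor), compound 1 gives 73.7 nM, while compound 2, which carries an extra fluoro group, gives 21.6 nM. The change between them, (fluoro in place of hydrogen on an aromatic carbon), yields a 3.4-fold lower number from compound 1 to compound 2 (0.53 log units; beyond the scatter). Compound 3 gives 331 nM in this assay, the highest of the three measured numbers; how the core of compound 3 differs from the core of compound 1 is not broken down here.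

Compound 4 `CNC(=S)N/N=C/c1ncc(F)c2ccccc12` has not yet been measured. It differs from compound 3 by fluoro in place of hydrogen on an aromatic carbon. Within the data shown here, this is the same kind of change as the one from compound 1 to compound 2, but not the same: in compound 2 the fluoro sits on a six-membered aromatic ring of carbon only, meta and para to a fused ring, whereas in compound 4 it sits on a six-membered aromatic ring with one nitrogen, ortho to a fused ring and two atoms from the ring nitrogen. Because the earlier step was a 3.4-fold lower number from compound 1 to compound 2 (0.53 log units; beyond the scatter), a smaller improvement is expected here, since the place is not the same and the core is different; the expected step is a 1.7-fold lower number from compound 3 to compound 4 (0.24 log units; within the scatter). Compound 4 is therefore estimated at 190 nM, roughly between 70 nM and 550 nM.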

Compound 4, half-maximal inhibitory concentration: 114 nM
For compound 4 the middle estimate is 1.7-fold (0.22 log units) above the measured one, and the stated range covers the measured number.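

Fluoro in place of hydrogen on an aromatic carbon lowers the number in this assay on a second core as well, giving a 2.9-fold lower number from compound 3 to compound 4 (0.46 log units; beyond the scatter), and the size of the gain carries over closely: the same change on two cores in this assay, a 3.4-fold lower number (0.53 log units; beyond the scatter) from compound 1 to compound 2 and a 2.9-fold lower number (0.46 log units; beyond the scatter) from compound 3 to compound 4, 1.2-fold (0.07 log units) apart, within the scatter of two such steps. This holds even though the fluoro stands on a six-membered aromatic ring of carbon only in compound 2 and on a six-membered aromatic ring with one nitrogen in compound 4, so in these two pairs neither the core nor the place changes the outcome by more than the scatter. Two pairs are still only two cases: they do not show that the change would carry over to a further core or another place, and they do not explain why the number falls.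

The compounds shown leave open whether fluoro is needed at all, or whether chloro, methoxy or an amine in the same place would serve as well. They also leave open what two fluoro groups on one core, one in each of these places, would do.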